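A few compounds are considered here, and "the series" means these few. Any claim that something is new, unique, unknown or untested is made for them only; others in the source may bear on it.

Compound 1 `CC(C(=O)NCc1ccc(C(F)(F)F)cc1N1CCCC1)c1ccc(NS(C)(=O)=O)c(F)c1`: 2.3 nM
Compound 2 `CC1CCN(c2cc(C(F)(F)F)ccc2CNC(=O)C(C)c2ccc(NS(C)(=O)=O)c(F)c2)CC1`: 0.9 nM
Compound 3 `CC(C(=O)NCc1ccc(C(F)(F)F)cc1N1CCN(c2ccccc2)CC1)c1ccc(NS(C)(=O)=O)c(F)c1`: 2 nM

These three compounds share one core and differ only in the cyclic amine attached to an aromatic carbon. In an assay on CHO cells for antagonist activity at transient receptor potential cation channel subfamily V member 1 (Homo sapiens), read by FLIPR (a lower number here means a stronger inhibitor, a higher number a weaker inhibitor), compound 3 gives 2 nM, the second highest of the three numbers; it sits closest to compound 1, whose value is 2.3 nM, with a 1.2-fold lower number from compound 1 to compound 3 (0.06 log units; within the scatter), and furthest from compound 2, whose value is 0.9 nM, with a 2.2-fold higher number from compound 2 to compound 3 (0.35 log units; beyond the scatter).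

Compound 4 `Cc1cccc(N2CCN(c3cc(C(F)(F)F)ccc3CNC(=O)C(C)c3ccc(NS(C)(=O)=O)c(F)c3)CC2)c1` is not yet measured. It arises from compound 3 by methyl in place of hydrogen on an aromatic carbon, placed meta to a large group; seen one bond further out, the change reads phenyl to 3-methylphenyl. For the measured compounds named here, none of the measured steps touches this outer phenyl: a 2.6-fold lower number from compound 1 to compound 2 (0.41 log units; beyond the scatter), a 1.2-fold lower number from compound 1 to compound 3 (0.06 log units; within the scatter) and a 2.2-fold higher number from compound 2 to compound 3 (0.35 log units; beyond the scatter) all exchange the whole amine ring, and even those exchanges stay modest. A single methyl at the far end of the amine is therefore expected to move the number less than any of them, in no fixed direction. Compound 4 is estimated at 1.8 nM, between 0.7 nM and 5 nM, a step of a 1.1-fold lower number from compound 3 to compound 4 (0.05 log units; within the scatter) that is expected to stay within the scatter.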

Compound 4, inhibition constant: 1.8 nM
The estimate for compound 4 equals the measured number at the digits printed, and the stated range covers the measured number.
By their numbers in this assay, from the lowest: compounds 2, 4, 3 and 1 (each within the scatter of the next, the first and the last beyond it).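

In this assay, the change from phenyl to 3-methylphenyl, methyl in place of hydrogen on an aromatic carbon meta to a large group, gives a 1.1-fold lower number from compound 3 to compound 4 (0.05 log units; within the scatter). The earlier steps all exchanged the whole amine ring, so this is the only step shown that keeps the ring and alters the far phenyl, and it shows that this aromatic carbon can carry a methyl with no difference that can be told from the scatter. Nothing measured here bears on why the number stays where it is, and no explanation can be offered for this result.

On these data alone, a single small group at a single carbon says little about this phenyl as a whole, so it remains open whether methoxy, chlorine or trifluoromethyl at the same carbon, or methyl at another carbon of the same ring, would leave the number equally undisturbed. Also open, as far as these compounds go, is whether a group of a different kind there, such as a carboxylic acid or an amine, would give a step beyond the scatter from compound 3.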